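The compounds below may be only part of what the source reports. "The series", "measured", "known", "first", "only" and "open" are said of these compounds alone.

Measured so far in a functional assay on IMR-32 cells for inhibition of Voltage-dependent N-type calcium channel subunit alpha-1B (Homo sapiens), read by calcium flux; on this read-out higher numbers stand for weaker inhibition and lower numbers for stronger inhibition:
compound 1 `COC(=O)c1cccc(C2C(C(=O)O)=C(C)N=C(C)/C2=C(/O)OC/C=C/c2ccccc2)c1`; compound 1 gives 4600 nM
compound 2 `CC1=NC(C)=C(C(=O)O)C(c2cccc(F)c2)/C1=C(\O)OC/C=C/c1ccccc1`; compound 2 gives 1300 nM
compound 3 `CC1=NC(C)=C(C(=O)O)C(c2cccc(Cl)c2)/C1=C(\O)OC/C=C/c1ccccc1`; compound 3 gives 1000 nM

Compound 3 has the lowest number of the three; its gap to compound 2 lies within the scatter, so no order can be set between those two, while compound 1 stands clearly higher. Compound 4 `CC1=NC(C)=C(C(=O)O)C(c2ccsc2)/C1=C(\O)OC/C=C/c1ccccc1` carries thiophen-3-yl in place of 3-chlorophenyl on a saturated ring carbon. Among the compounds with values here, no measured step exchanges the aromatic ring itself; the three known steps vary only a substituent on that ring and were a 3.5-fold lower number from compound 1 to compound 2 (0.55 log units; beyond the scatter), a 4.6-fold lower number from compound 1 to compound 3 (0.66 log units; beyond the scatter) and a 1.3-fold lower number from compound 2 to compound 3 (0.11 log units; within the scatter). Within the data shown here, an exchange of the whole ring therefore has no direct counterpart, and the expected step of a 2.0-fold higher number from compound 3 to compound 4 (0.30 log units; within the scatter) is kept small, toward a somewhat higher number, with a wide range. In this assay compound 4 is estimated at 2000 nM, between 700 nM and 6000 nM.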

Compound 4, half-maximal inhibitory concentration: 2900 nM
Estimate against measurement, compound 4: 1.5-fold (0.16 log units) below; the measured number falls inside the stated range.
By their numbers in this assay, from the lowest: compounds 3 and 2 (each within the scatter of the next); then compounds 4 and 1 (each within the scatter of the next).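

In this assay, thiophen-3-yl on the saturated ring carbon gives a 2.9-fold higher number from compound 3 to compound 4 (0.46 log units; beyond the scatter) and a 2.2-fold higher number from compound 2 to compound 4 (0.35 log units; beyond the scatter) and so shows that exchanging the whole aromatic ring, not only its substituent, moves the number at this position. The exchange from 3-(methoxycarbonyl)phenyl gives a 1.6-fold lower number from compound 1 to compound 4 (0.20 log units; within the scatter) and leaves those two groups without an order. No evidence on the cause of these steps is available. Going by these compounds, whether a chloro group on the thiophen-3-yl ring would bring the number back toward those of the halogenated phenyl compounds stays open, as does the outcome with a pyridin-3-yl or cyclohexyl ring.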